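This account rests on a few compounds, and the source may have more. Where it says the series, first, only, none or still open, it means among the compounds named here.

Measured in a functional assay on OVCAR-8 cells (Homo sapiens) for inhibition, read by sulforhodamine B assay, with a stated time of 48 h; on this read-out higher numbers stand for weaker inhibition of growth and lower numbers for stronger inhibition of growth:
Compound 1 `Cc1nnc(-c2nn(-c3ccccc3)c(-c3ccccc3)c2C#N)c2cn(-c3ccccc3)nc12`: > 100000 nM, a limit of the assay and not a number.
Compound 2 `N#Cc1c(-c2nnc(O)c3nn(-c4ccccc4)cc23)nn(-c2ccccc2)c1-c1ccccc1`: 61500 nM.
Compound 3 `N#Cc1c(-c2nnc(-c3ccccc3)c3nn(-c4ccccc4)cc23)nn(-c2ccccc2)c1-c1ccccc1`: 68000 nM.

Compound 3 stands level with compound 2, the step being a 1.1-fold higher number from compound 2 to compound 3 (0.04 log units; within the scatter). Compound 4 `Cc1ccc(-n2cc3c(-c4nn(-c5ccccc5)c(-c5ccccc5)c4C#N)nnc(-c4ccccc4)c3n2)cc1` differs from compound 3 by methyl in place of hydrogen on an aromatic carbon, phenyl to 4-methylphenyl: methyl in place of hydrogen on an aromatic carbon. Among the compounds with values here, no measured step touches that ring. The steps measured elsewhere on these compounds, an at least 1.6-fold lower number from compound 1 to compound 2 (0.21 log units; that floor lies within the scatter) and an at least 1.4-fold lower number from compound 1 to compound 3 (0.16 log units; that floor lies within the scatter), bear on it only loosely, and neither is shown to exceed the scatter. In this assay, therefore, no step beyond the scatter is expected. The expected step is a 1.0-fold lower number from compound 3 to compound 4 (0.02 log units; within the scatter). The estimate for compound 4 is 65000 nM, with an expected range of 30000 nM to 100000 nM.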

Compound 4, concentration for 50% growth inhibition: 9230 nM
Beside the measured number, compound 4's estimate is 7.0-fold (0.85 log units) above it, and the stated range ends above it.
By their numbers in this assay, from the lowest: compound 4; then compounds 2 and 3 (each within the scatter of the next). At a limit, above all of these: compound 1.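

This is the first step shown beyond the scatter, and it falls on a ring no earlier step touched: in this assay, phenyl to 4-methylphenyl gives a 7.4-fold lower number from compound 3 to compound 4 (0.87 log units; beyond the scatter). A single methyl on an aromatic carbon para to a large group is therefore enough to change growth inhibition, while the hydroxy-to-phenyl step elsewhere on the core stayed within the scatter. The steps from compound 1 give only floors: the limit of > 100000 nM in this assay, at which 1 of the 4 values shown sits.

The compounds shown leave open whether a methoxy, a chloro or an amine at this place would act like methyl. They also leave open whether methyl here gives a similar step when hydroxy replaces the phenyl of compound 3 elsewhere on the core.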